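The source may report more compounds than this note shows. Statements on the series, on what has been measured and on what is new or still open speak of the compounds shown alone.

Values in an ADME assay on MT4 cells (Homo sapiens) for activation, read by MTT assay; a lower number here means that less compound is tolerated, a higher number that more compound is tolerated:
- Compound 1 `CCCCSc1nc(C(C)c2c(F)cccc2Cl)cc(=O)[nH]1`: > 73000 nM, a limit
- Compound 2 `CCCSc1nc(C(C)c2c(F)cccc2Cl)c(CC)c(=O)[nH]1`: > 3000 nM, a limit
- Compound 3 `CCc1c(C(C)c2c(F)cccc2Cl)nc(SC(C)CC)[nH]c1=O`: > 3000 nM, a limit

Compound 3 has no exact number and stands at the limit of > 3000 nM in this assay, at which 2 of the 3 values shown sit. Compound 4 `CCCCSc1nc(C(C)c2c(F)cccc2Cl)c(CC)c(=O)[nH]1` differs from it as follows: butyl in place of sec-butyl on a sulfur. That is butyl in place of sec-butyl on a sulfur. The nearest measured change, a step that the two limits leave unreadable from compound 2 to compound 3, also lies in the chain on that sulfur, but it gives neither a size nor a direction. Compound 1 also carries butyl on a sulfur, and its value is the limit > 73000 nM. No step beyond the scatter is therefore expected in this assay. The expected step is a step that the limit leaves unreadable from compound 3 to compound 4. Compound 4 is estimated at 20000 nM, within an expected range of 3000 nM to 100000 nM.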

Compound 4, half-maximal cytotoxic concentration: > 3000 nM
Compound 4: no number, only a limit (the forecaster's own chance of this, stated with the estimate: 80%); the middle value does not contradict the limit.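

In this assay compound 4 gives only a limit, and its steps from compound 1, compound 2 and compound 3 cannot be read. The compounds shown leave open whether butyl and sec-butyl on the sulfur differ at all in this assay.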